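The source may hold more compounds than are shown below. What is called first, only, known or untested is meant among the compounds shown, and "the series" means these compounds.

In a functional assay on SK-OV-3 cells (Homo sapiens) for inhibition, read by sulforhodamine B assay, with a stated time of 48 h (a lower number here means that less compound is tolerated, a higher number that more compound is tolerated), compound 2 `Cc1nn(-c2ccccc2)cc1/C=N/Nc1nc(Nc2ccccc2)nc(Nc2ccc(S(N)(=O)=O)cc2)n1` is recorded only as a limit, > 100000 nM. The same holds for compound 1 `NS(=O)(=O)c1ccc(Nc2nc(N/N=C/c3ccc(C(F)(F)F)cc3)nc(Nc3ccccc3)n2)cc1`, whose value in this assay is likewise the limit > 100000 nM. For the measured compounds named here, the one step between measured compounds, a step that the two limits leave unreadable from compound 1 to compound 2, cannot therefore be read in size or direction, and the limit of > 100000 nM in this assay, at which 2 of the 2 values shown sit, is all that the two measured compounds show. Compound 3 `NS(=O)(=O)c1ccc(Nc2nc(N/N=C/c3ccccn3)nc(Nc3ccccc3)n2)cc1` differs from compound 2 in a single place: pyridin-2-yl in place of 3-methyl-1-phenyl-1H-pyrazol-4-yl on a carbon with a double bond to nitrogen. Going by the values given here, no measured step bears directly on that change; the only recorded step concerns a different group on the same carbon, and its size is unreadable. With nothing readable to build on, the change implied by the estimate in this assay is expected to be a step that the limit leaves unreadable from compound 2 to compound 3, resting on the limit of > 100000 nM in this assay, at which 2 of the 2 values shown sit, rather than on any observed trend. Compound 3 is accordingly estimated at 150000 nM, with a range from 30000 nM to 600000 nM, and in this assay the result is most likely to be reported once more only as a limit.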

Compound 3, concentration lethal to 50% of the cells: > 100000 nM
Compound 3: only a limit was reported; the forecaster's own chance of this, stated with the estimate: 80%; the middle value is on the limit's open side.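

In this assay compound 3 is recorded at > 100000 nM as a limit of the assay, not a number. For the compounds shown here, no step from compound 1 or compound 2 to compound 3 can be read, in size or direction: the limit of > 100000 nM in this assay, at which 3 of the 3 values shown sit. The compounds shown leave open whether the groups on the carbon with a double bond to nitrogen differ at all in this assay and how far each compound's true value lies past the limit.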